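The compounds below may be only part of what the source reports. "The series", "measured", "known", "first", "only" and "open" are said of these compounds alone.

Measured so far in an ADME assay (liver) for metabolic stability, with Liver microsome (Homo sapiens) as the target, using microsomes and NADPH, with a stated time of 30 min, tested at 1 uM; a higher number here means faster removal of the compound, a lower number slower removal:
Compound 1 `COc1cc(C(O)(C(F)(F)F)C(F)(F)F)cnc1N1CCN(S(=O)(=O)c2ccc(N)nc2)CC1` gives < 14 mL.min-1.g-1, which is a limit of the assay rather than a number.
Compound 2 `COCC#Cc1cc(C(O)(C(F)(F)F)C(F)(F)F)cnc1N1CCN(S(=O)(=O)c2ccc(N)nc2)CC1` gives 15 mL.min-1.g-1.
Compound 3 `Nc1ccc(S(=O)(=O)N2CCN(c3ncc(C(O)(C(F)(F)F)C(F)(F)F)cc3-c3ccccc3O)CC2)cn1` gives 22 mL.min-1.g-1.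

Compound 3 holds the higher of the two numbers shown. Compound 2 is its nearest neighbour, with a 1.5-fold higher number from compound 2 to compound 3 (0.17 log units; within the scatter), and from compound 1 the step is an at least 1.5-fold higher number from compound 1 to compound 3 (0.19 log units; that floor lies within the scatter), so neither step separates compound 3 from the rest. Compound 4 `Nc1ccc(S(=O)(=O)N2CCN(c3ncc(C(O)(C(F)(F)F)C(F)(F)F)cc3-c3ccc4c(c3)CC(=O)N4)CC2)cn1` changes compound 3 at the same aromatic carbon that was varied in those steps: a group of 10 heavy atoms (8 carbon, 1 nitrogen, 1 oxygen; one five-membered non-aromatic ring with 1 hetero atom, one six-membered aromatic ring of carbon only) in place of a group of 7 heavy atoms (6 carbon, 1 oxygen; one six-membered aromatic ring of carbon only), on an aromatic carbon. Among the compounds with values here, the steps that bear on this position, an at least 1.0-fold higher number from compound 1 to compound 2 (0.02 log units; that floor lies within the scatter), an at least 1.5-fold higher number from compound 1 to compound 3 (0.19 log units; that floor lies within the scatter) and a 1.5-fold higher number from compound 2 to compound 3 (0.17 log units; within the scatter), all stay within the scatter, and none of them covers the group that enters here, so the step remains an extrapolation. On that basis a step in this assay beyond the scatter is not expected in either direction. The estimate for compound 4 is 25 mL.min-1.g-1 with a range of 12 mL.min-1.g-1 to 55 mL.min-1.g-1. This estimate means an expected step of a 1.1-fold higher number from compound 3 to compound 4 (0.06 log units; within the scatter).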

Compound 4, intrinsic clearance in microsomes: < 14 mL.min-1.g-1
Compound 4 gave a limit, no number; the forecaster's own chance of this, stated with the estimate: 15%; middle value at least 1.7-fold (0.25 log units) away from the limit.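

In this assay compound 4 sits at a limit of the assay, so its steps are known only as floors: an at least 1.5-fold lower number from compound 3 to compound 4 (0.19 log units; that floor lies within the scatter) and an at least 1.0-fold lower number from compound 2 to compound 4 (0.02 log units; that floor lies within the scatter). The position two atoms from the ring nitrogen thus carries the largest group shown, with a five-membered non-aromatic ring alongside the six-membered aromatic ring, and the number does not rise beyond the scatter. The step between the other two compounds cannot be read because both stand at the limit: the limit of < 14 mL.min-1.g-1 in this assay, at which 2 of the 4 values shown sit.

Going by these compounds, whether compound 4 truly separates from compound 3 by more than the scatter stays open. Also open, on these data alone, is how a carboxylic acid or a primary amine at this position would read in this assay.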